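A Chloroacetamide Arm Added to an Inactive Core

A few compounds are considered here, and "the series" means these few. Any claim that something is new, unique, unknown or untested is made for them only; others in the source may bear on it.

Compound 1 `O=c1nc(NO)cc[nH]1`, compound 2 `Cc1cc(=O)[nH]c(=O)n1COC(CO)CO` and compound 3 `O=c1ccn(COC(CO)CO)c(=O)[nH]1` have all been tested in the same way. In a functional assay on HeLa cells (Homo sapiens) for inhibition, read by MTT assay, with a stated time of 72 h (on this read-out higher numbers stand for weaker inhibition and lower numbers for stronger inhibition), compound 1 reaches only a limit of the assay, > 100000 nM. In this assay compound 2 likewise reaches only a limit, > 100000 nM. Compound 3 also gives a limit, > 100000 nM. The step that the two limits leave unreadable from compound 2 to compound 3 therefore cannot be read, and the limit of > 100000 nM in this assay, at which 3 of the 3 values shown sit, shows that every value gathered so far stops at the same limit, so compound 3 stands at that limit alongside the other two, with no number to rank it.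

Compound 4 `O=C(CCl)Nc1cn(COC(CO)CO)c(=O)[nH]c1=O` differs from compound 3 by ((chloromethyl)carbonyl)amino in place of hydrogen on an aromatic carbon. Going by the values given here, no measured step has a readable size, so nothing in the measured data supports expecting a shift beyond the scatter in either direction. The estimate for compound 4 is 80000 nM, with a range from 15000 nM to 300000 nM. For compound 4 this amounts to an expected step of an at least 1.2-fold lower number from compound 3 to compound 4 (0.09 log units; that floor lies within the scatter).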

Compound 4, half-maximal inhibitory concentration: 12000 nM
The estimate for compound 4 lay 6.7-fold (0.82 log units) above the measured number; the measured number lies below the stated range.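

Placing ((chloromethyl)carbonyl)amino on this aromatic carbon, two atoms from the ring nitrogen, gives in this assay an at least 8.3-fold lower number from compound 3 to compound 4 (0.92 log units; beyond the scatter). Going by these compounds alone, this is the first step of readable size, and it shows that a change at this one position can move the read-out on HeLa cells, which the earlier compounds could not show. Compound 4 is the only compound here with a number rather than a limit, so its step has a floor but no known full size, and the other compounds offer no number to rank it against: the limit of > 100000 nM in this assay, at which 3 of the 4 values shown sit.

What the compounds shown leave open is whether the chlorine is needed, since a plain acetamide or an amine at this carbon would separate the chlorine from the rest of the arm. They also leave open whether a longer chain in place of the chloromethyl part would keep, lose or add to this step.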